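A few compounds are considered here, and "the series" means these few. Any claim that something is new, unique, unknown or untested is made for them only; others in the source may bear on it.

Working notes on the series. Compound 1 `CN(C(=O)c1cc(Cl)c(=O)n(Cc2c(Cl)cccc2Cl)c1)c1ccccc1` in an assay on isolated protein for inhibition of P2X purinoceptor 7 (Homo sapiens) (a lower number here means a stronger inhibitor, a higher number a weaker inhibitor), gives 126 nM. Compound 2 `O=C1CC[C@@H](C(=O)NCc2ccc(F)cc2Cl)N1` is reported only as a limit of this assay, not as a number: compound 2 gives < 1000 nM. On the numbers shown, compound 2 therefore stands only at a limit, (the limit of < 1000 nM in this assay, at which 1 of the 2 values shown sits). Going by the values given here, no step between measured compounds can be drawn here, and the value of compound 1 and the limit of compound 2 cannot be set against each other. Compound 3 `CCCN1C(=O)CC[C@H]1C(=O)NCc1ccc(F)cc1Cl` differs from compound 2 by propyl in place of hydrogen on an amide-type nitrogen in a ring. Among the compounds with values here, with no measured step to rest on, the change from compound 2 to compound 3 is expected to stay within the scatter of this assay, in no clear direction. Compound 3 is thus expected at 500 nM, with a range from 100 nM to 3000 nM. The step this estimate implies, a step that the limit leaves unreadable from compound 2 to compound 3, is expected to remain within the usual scatter.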

Compound 3, half-maximal inhibitory concentration: 158 nM
The estimate for compound 3 lay 3.2-fold (0.50 log units) above the measured number, within the range that was stated.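

Going by these compounds alone, no step from compound 2 to compound 3 can be read, because compound 2 stands only at a limit: the limit of < 1000 nM in this assay, at which 1 of the 3 values shown sits.

The compounds shown leave open what size of change in this assay goes with propyl in place of hydrogen on an amide-type nitrogen in a ring.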